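From Sulfamoyl to Ethoxycarbonyl on the Shared Core

A few compounds are considered here, and "the series" means these few. Any claim that something is new, unique, unknown or untested is made for them only; others in the source may bear on it.

Compound 3 `NS(=O)(=O)c1ccc(NC2=CC(=O)c3ncncc3C2=O)cc1` is the weakest of the three measured compounds. In a functional assay on MIA PaCa-2 cells (Homo sapiens) for cytotoxicity, read by MTT assay, with a stated time of 72 h (a higher number here means a weaker inhibitor, a lower number a stronger inhibitor), compound 3 gives only a limit, > 10000 nM, the upper bound of this assay (the limit of > 10000 nM in this assay, at which 1 of the 3 values shown sits). Compound 1 `O=C1C(Nc2ccc(-c3ccccc3)cc2)=CC(=O)c2ncncc21` gives 900 nM in this assay, and compound 2 `COc1ccc(-c2ccc(NC3=CC(=O)c4ncncc4C3=O)cc2)cc1` gives 2100 nM. Compound 4 `CCOC(=O)c1ccc(NC2=CC(=O)c3ncncc3C2=O)cc1` differs from compound 3 by ethoxycarbonyl in place of sulfamoyl on an aromatic carbon. Both measured steps that introduce the sulfamoyl group went toward weaker inhibition: an at least 11-fold higher number from compound 1 to compound 3 (1.04 log units; beyond the scatter) and an at least 4.7-fold higher number from compound 2 to compound 3 (0.67 log units; beyond the scatter). Among the compounds with values here, no measured step shows what an ethoxycarbonyl group does in this place, and compound 3 itself is known only as a limit, so the step can be judged only roughly. Compound 4 is expected to give 8000 nM, within 2500 nM to 25000 nM, an expected step of an at least 1.2-fold lower number from compound 3 to compound 4 (0.09 log units; that floor lies within the scatter).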

Compound 4, half-maximal inhibitory concentration: 5500 nM
For compound 4 the middle estimate is 1.5-fold (0.16 log units) above the measured one, within the range that was stated.
By their numbers in this assay, from the lowest: compound 1; then compound 2; then compound 4. At a limit, above all of these: compound 3.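

Ethoxycarbonyl, which has no ring, gives a measured number where sulfamoyl gave only a limit, so a group without a ring at this place can still show inhibition, with an at least 1.8-fold lower number from compound 3 to compound 4 (0.25 log units; that floor lies within the scatter). That step is only a floor because compound 3 stands at a limit: the limit of > 10000 nM in this assay, at which 1 of the 4 values shown sits. Phenyl and 4-methoxyphenyl still give the lower numbers, with a 2.6-fold higher number from compound 2 to compound 4 (0.42 log units; beyond the scatter) and a 6.1-fold higher number from compound 1 to compound 4 (0.79 log units; beyond the scatter).

The compounds shown leave open how an amine, a carboxylic acid or a longer ester chain would compare at this place. As far as these compounds go, how far compound 3 truly lies from compound 4 also stays open.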